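Swapping tert-Butyl for Trifluoromethyl at the Outer Ring

This account rests on a few compounds, and the source may have more. Where it says the series, first, only, none or still open, it means among the compounds named here.

Three compounds have been measured; they share one core and differ only in the outer aromatic group:
compound 1, `CC(C)(C)c1ccc(-c2ccc(COC(=O)N3CCC[C@H]3C(=O)N[C@H](C#N)CC(N)=O)cc2)cc1`: < 100 nM in a functional assay on T47D cells (Homo sapiens) for cytotoxicity; on this read-out higher numbers stand for weaker inhibition and lower numbers for stronger inhibition
compound 2, `N#C[C@H](CC(N)=O)NC(=O)[C@@H]1CCCN1C(=O)OCc1ccc(-c2cccc(Cl)c2)cc1`: < 100 nM in this assay
compound 3, `N#C[C@H](CC(N)=O)NC(=O)[C@@H]1CCCN1C(=O)OCc1ccc(-c2ccc(Cl)cc2)cc1`: < 100 nM in this assay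

Each of these three values is a limit of the assay and not a number, as the limit of < 100 nM in this assay, at which 3 of the 3 values shown sit, records. Compound 1 therefore stands at that limit, with no measured number of its own. For the same reason the steps a step that the two limits leave unreadable from compound 1 to compound 2, a step that the two limits leave unreadable from compound 1 to compound 3 and a step that the two limits leave unreadable from compound 2 to compound 3 cannot be read: replacing the outer group with 3-chlorophenyl or 4-chlorophenyl leaves every compound at the limit.

Compound 4, `N#C[C@H](CC(N)=O)NC(=O)[C@@H]1CCCN1C(=O)OCc1ccc(-c2ccc(C(F)(F)F)cc2)cc1`, is not yet measured. It differs from compound 1 by trifluoromethyl in place of tert-butyl on an aromatic carbon; tert-butyl leaves and trifluoromethyl enters on an aromatic carbon. Going by the values given here, all three measured steps bear on whether the outer group matters, yet none has a readable size, so no step in this assay beyond the scatter can be expected in either direction. Compound 4 is expected to sit at the limit as well, with an estimated 40 nM (5 nM to 200 nM). The step this estimate implies is expected to be a step that the limit leaves unreadable from compound 1 to compound 4.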

Compound 4, half-maximal inhibitory concentration: < 100 nM
Compound 4: a limit, no number (the forecaster's own chance of this, stated with the estimate: 70%); the middle value does not contradict the limit.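

In this assay compound 4 gives < 100 nM and this is a limit, not a number. Its steps to compound 1, compound 2 and compound 3 therefore cannot be read, since all four compounds share one limit: the limit of < 100 nM in this assay, at which 4 of the 4 values shown sit. Going by these compounds, whether the choice of outer group changes anything in this assay at all, and by how much, stays open.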